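Cytotoxicity series: benzodioxinyl in place of dimethoxypyrimidinyl

This account rests on a few compounds, and the source may have more. Where it says the series, first, only, none or still open, it means among the compounds named here.

Three compounds of this series have been run in an ADME assay on BJ cells (Homo sapiens) for cytotoxicity, read by CellTiter-Glo and resazurin assay, with a stated time of 72 h; on this read-out lower numbers stand for an effect already at smaller amounts and higher numbers for an effect only at larger amounts of compound. Compound 1 `CC(C)N(Cc1cccc(OCCCCCC(=O)O)c1)C(=O)c1ccc(-c2cccc(N(C)C)c2)cc1` reaches only a limit, and in this assay compound 1 gives > 26000 nM. Compound 2 `CC(C)Oc1cccc(-c2ccc(C(=O)N(Cc3cccc(OCCCCCC(=O)O)c3)C(C)C)cc2)c1` likewise stops at a limit, giving in this assay > 26000 nM. Compound 3 `CCOC(=O)CCCCCOc1cccc(CN(C(=O)c2ccc(-c3cnc(OC)nc3OC)cc2)C(C)C)c1` also gives only a limit in this assay, namely > 26000 nM. For the measured compounds named here, the one step between measured neighbours, a step that the two limits leave unreadable from compound 1 to compound 2, cannot be read in size because the limit of > 26000 nM in this assay, at which 3 of the 3 values shown sit, holds both of its ends. Compound 3 thus stands at that same limit, with nothing in the numbers setting it apart from compound 1 or compound 2.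

Compound 4 `CCOC(=O)CCCCCOc1cccc(CN(C(=O)c2ccc(-c3ccc4c(c3)OCCO4)cc2)C(C)C)c1` is not yet measured. It differs from compound 3 by 2,3-dihydro-1,4-benzodioxin-6-yl in place of 2,4-dimethoxypyrimidin-5-yl on an aromatic carbon. Going by the values given here, no measured step bears on this change: the only step recorded is unreadable and concerns a different part of the molecule. All three values sit at the limit of > 26000 nM in this assay, at which 3 of the 3 values shown sit, so no readable size of step is available, and none beyond the scatter is expected in this assay for this change. The step that the limit leaves unreadable from compound 3 to compound 4 is therefore estimated as essentially flat. Compound 4 is expected to give about 40000 nM, within 20000 nM to 100000 nM, most likely again reported only as a limit.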

Compound 4, half-maximal effective concentration: > 24400 nM
Compound 4 was reported as a limit; the forecaster's own chance of this, stated with the estimate: 85%; the middle value lies beyond the limit too.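

Compound 4 gives > 24400 nM as a limit in this assay and compound 3 likewise gives only a limit, leaving the step between compound 3 and compound 4 unreadable. The compounds shown leave open at what concentration, if any, an effect appears in this assay and whether 2,3-dihydro-1,4-benzodioxin-6-yl and 2,4-dimethoxypyrimidin-5-yl differ at all.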